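Nonyl chain extension on two cores: estimating compound 4

The source may hold more compounds than are shown below. What is called first, only, known or untested is meant among the compounds shown, and "the series" means these compounds.

Measured in a functional assay on cells (Lymphocyte, Homo sapiens), read by trypan blue exclusion, with a stated time of 16 h, tested at 0.1 uM; a lower number here means a weaker effect, a higher number a stronger effect of the compound at the concentration tested: compound 1 `CCCCCCCCCCc1c(C)c(N(C)C)nc(C)c1O` gives 34%; compound 2 `CCCCCCCCCCc1nc(N(C)C)c(C)c(C)c1O` gives 36%; compound 3 `CCCCCCCCCCCCCCCCCCCc1c(C)c(N(C)C)nc(C)c1O` gives 20%.

Compound 1 and compound 3 differ in one place: nonyl in place of hydrogen on a saturated chain carbon, ten or more bonds along the chain from an aromatic carbon. This change gave a number 14 percentage points lower from compound 1 to compound 3 (beyond the scatter). Compound 1 and compound 2 are built from the same atoms joined differently; the difference between the two cores is not broken down here. Compound 2 and compound 1 give values within the usual scatter of each other.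

Compound 4 `CCCCCCCCCCCCCCCCCCCc1nc(N(C)C)c(C)c(C)c1O` has not yet been measured. It differs from compound 2 by nonyl in place of hydrogen on a saturated chain carbon, ten or more bonds along the chain from an aromatic carbon, the same change as from compound 1 to compound 3. The step is expected to be a number 14 percentage points lower from compound 2 to compound 4 (beyond the scatter) because the same change earlier gave a number 14 percentage points lower from compound 1 to compound 3 (beyond the scatter). Compound 4 is therefore expected to give about 22%, estimated between 10% and 34%.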

Compound 4, a percentage reported as activity, at one concentration (the size of the read-out at that concentration, not a potency): 17%
Compound 4: the middle estimate sits 5 percentage points above what was measured; the measured number falls inside the stated range.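

In this assay, the nonyl extension lowers the number on the second core as well, with a step of a number 19 percentage points lower from compound 2 to compound 4 (beyond the scatter) on that core. Across the two cores the size of the step holds within the scatter: the same change on two cores in this assay, a number 14 percentage points lower (beyond the scatter) from compound 1 to compound 3 and a number 19 percentage points lower (beyond the scatter) from compound 2 to compound 4, 5 percentage points apart, within the scatter of two such steps. For the compounds shown here, this rests on only two matched pairs at a single concentration, so it does not show that the step would keep its size on any other core, and it gives no reason for the drop.

The compounds shown leave open how the number moves with chains of intermediate length, or with a shorter chain such as hexyl. They also leave open whether a chain ending in an amine or a carboxylic acid would behave the same way on either core.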